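Nitrile for Chloride on the Anilide of Compound 1

This account rests on a few compounds, and the source may have more. Where it says the series, first, only, none or still open, it means among the compounds named here.

Measured compounds:
compound 1, `N#Cc1cc(Cl)ccc1NC(=O)c1ccc2cccnc2c1O`: 3540 nM
compound 2, `O=C(Nc1ccc(Cl)cc1)c1ccc2cccnc2c1O`: 3300 nM
compound 3, `O=C(Nc1ccc(C(F)(F)F)cc1)c1ccc(F)cc1O`: 740 nM

In a functional assay on KG-1 cells (Homo sapiens) for cytotoxicity, read by luminescence and CellTiter-Glo, with a stated time of 3 days (a higher number here means a weaker inhibitor, a lower number a stronger inhibitor), compound 1 gives 3540 nM, the highest of the three numbers. Among the compounds with values here, its nearest neighbour is compound 2, at 3300 nM; the furthest is compound 3, at 740 nM, which lies beyond the scatter from compound 1 but shares no single-point step with it.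

Within the data shown here, the new compound 4, `N#Cc1ccc(NC(=O)c2ccc3cccnc3c2O)c(C#N)c1`, differs from compound 1 in one place: cyano in place of chloro on an aromatic carbon The only measured step on this core, a 1.1-fold lower number from compound 1 to compound 2 (0.03 log units; within the scatter), concerns a different position and a different pair of groups, yet it shows that trading a cyano for hydrogen on the anilide ring moved the number hardly at all. Among the measured compounds shown here, no measured step touches the chloro itself, so the expectation rests on that single step and carries little weight.

The account therefore expects compound 4 to stay close to compound 1 in this assay, with a 1.2-fold lower number from compound 1 to compound 4 (0.07 log units; within the scatter) likely inside the scatter. The estimate for compound 4 is 3000 nM, with a range from 1200 nM to 7500 nM.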

Compound 4, half-maximal inhibitory concentration: 3770 nM
Compound 4: the middle estimate sits 1.3-fold (0.10 log units) below what was measured; the measured number falls inside the stated range.
By their numbers in this assay, from the lowest: compound 3; then compounds 2, 1 and 4 (each within the scatter of the next).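

In this assay, within the data shown here, the step of a 1.1-fold higher number from compound 1 to compound 4 (0.03 log units; within the scatter) is the first measured change at the carbon that carries the chloro, para to a large group and meta to a cyano group. The earlier compounds shown here showed only what happens when the other cyano group on this ring gives way to hydrogen, so they said nothing about this carbon, whereas here a single chlorine is exchanged for a cyano of 2 heavy atoms with 1 hydrogen-bond acceptor, and the two numbers still lie within the scatter of each other. Taken with the earlier step, this means that neither of the two single changes measured on this ring separates its compounds in this assay, and nothing available explains why these compounds read alike.

The compounds shown leave open whether this carbon would read the same with a group of another kind, such as an amine, a carboxylic acid or a longer chain. Compound 3 differs from these compounds in more than one place, so it cannot show whether the same exchange would give a similar result on another core.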